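The source may hold more compounds than are shown below. What is called first, only, known or untested is meant among the compounds shown, and "the series" means these compounds.

Compound 1 `COc1cccc(N2C(=O)COc3ccc(-c4cnc(Cl)c(NS(=O)(=O)c5ccc(F)cc5)c4)cc32)c1` was examined in a functional assay on HCT-116 cells (Homo sapiens) for antiproliferative activity, read by MTT assay, with a stated time of 72 h; a lower number here means a stronger inhibitor, a higher number a weaker inhibitor. In this assay compound 1 gives only a limit, > 40000 nM. Compound 2 `COc1cccc(N2C(=O)COc3ccc(-c4cnc(OC)c(NS(=O)(=O)c5ccc(F)cc5)c4)cc32)c1` likewise gives only a limit in this assay, > 40000 nM. Going by the values given here, the single measured step, a step that the two limits leave unreadable from compound 1 to compound 2, is therefore of unreadable size. Compound 3 `O=C1COc2ccc(-c3cnc(Cl)c(NS(=O)(=O)c4ccc(F)cc4)c3)cc2N1c1ccc(F)cc1` differs from compound 1 by 4-fluorophenyl in place of 3-methoxyphenyl on an amide-type nitrogen in a ring. Among the compounds with values here, no measured step covers this change; the only evidence is the limit of > 40000 nM in this assay, at which 2 of the 2 values shown sit. For compound 3 a value at or near the same limit is expected, with no readable step a number no higher from compound 1 to compound 3 (the limit leaves the size open). The estimate for compound 3 is 40000 nM, between 20000 nM and 80000 nM.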

Compound 3, half-maximal inhibitory concentration: 34200 nM
Compound 3: the middle estimate sits 1.2-fold (0.07 log units) above what was measured; low and high end bracket the measured number.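

In this assay, compound 3 gives 34200 nM, the first number shown rather than a limit. Placing 4-fluorophenyl instead of 3-methoxyphenyl on the amide-type nitrogen in a ring gives an at least 1.1-fold lower number from compound 1 to compound 3 (0.06 log units; that floor lies within the scatter), so this position tolerates the change, but no step beyond the scatter can be claimed. Limits still make up most of the values shown: the limit of > 40000 nM in this assay, at which 2 of the 3 values shown sit.

Going by these compounds, whether an amine, a carboxylic acid or a longer chain at this position would give a much lower number remains open. So does whether 4-fluorophenyl would give a number with methoxy in place of chloro.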